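Substituted Phenyl Rings Against Unsubstituted in the Shared Core

A few compounds are considered here, and "the series" means these few. Any claim that something is new, unique, unknown or untested is made for them only; others in the source may bear on it.

Compound 3, `O=C(C/C=C/c1ccccc1)Nc1nc2ccccc2c(=O)s1`, is the only one of the three measured compounds with an actual number in an assay on CHO cells for displacement of a labelled ligand from adenosine receptor A2b (Homo sapiens), read by scintillation counting, with a stated time of 75 min; on this read-out lower numbers stand for stronger inhibition and higher numbers for weaker inhibition: in that assay compound 3 gives 119 nM. Compound 1, `COc1cccc(/C=C/CC(=O)Nc2nc3ccccc3c(=O)s2)c1`, reaches only a limit of the assay; in this assay compound 1 gives >= 1000 nM. Compound 2, `O=C(C/C=C/c1cccc(Cl)c1)Nc1nc2ccccc2c(=O)s1`, likewise stops at a limit; in this assay compound 2 gives > 1000 nM. The step between them, a step that the two limits leave unreadable from compound 1 to compound 2, therefore cannot be sized. Compound 4, `O=C(C/C=C/c1ccc(Cl)c(Cl)c1)Nc1nc2ccccc2c(=O)s1`, has not yet been measured; it differs from compound 3 by 3,4-dichlorophenyl in place of phenyl on a double-bonded chain carbon bound to a double-bonded chain carbon. For the measured compounds named here, two measured steps bear on this change: an at least 8.4-fold lower number from compound 1 to compound 3 (0.92 log units; beyond the scatter) and an at least 8.4-fold lower number from compound 2 to compound 3 (0.92 log units; beyond the scatter). Both show that removing a substituent from the aromatic ring lowered the number, so placing substituents on it, here two chlorines, is expected to raise it. The expected step of a 13-fold higher number from compound 3 to compound 4 (1.10 log units; beyond the scatter) thus points toward weaker binding, and compound 4 may well end at a limit. Compound 4 is estimated at 1500 nM, with a range from 400 nM to 6000 nM.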

Compound 4, inhibition constant: > 1000 nM
Compound 4 was reported as a limit; the forecaster's own chance of this, stated with the estimate: 60%; the middle value is on the limit's open side.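

With 3,4-dichlorophenyl in place of phenyl, this assay shows an at least 8.4-fold higher number from compound 3 to compound 4 (0.92 log units; beyond the scatter). The earlier substituted compounds carried one methoxy or one chloro on the ring, whereas compound 4 extends the same direction to a ring with two chlorines, and none of the four compounds goes against it: only the unsubstituted phenyl of compound 3 gives an actual number. The steps from compound 1 and from compound 2 to compound 4 cannot be read, because both ends of each are limits of the assay rather than numbers: the limit of > 1000 nM in this assay, at which 2 of the 4 values shown sit.

The compounds shown leave open how far the number rises beyond these limits for any of the substituted rings. They also leave open whether a smaller group such as fluoro, or an amine or a hydroxyl on the ring, would keep the number near that of compound 3.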